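Swapping Methoxy for Fluoro on a Biaryl Iminosugar

This account rests on a few compounds, and the source may have more. Where it says the series, first, only, none or still open, it means among the compounds named here.

Compound 1 `COc1cccc(-c2ccc(COCCCCCN3C[C@H](O)[C@@H](O)[C@H](O)[C@H]3CO)cc2)c1` and compound 2 `COc1ccccc1-c1ccc(COCCCCCN2C[C@H](O)[C@@H](O)[C@H](O)[C@H]2CO)cc1` share one core and differ only in where a methoxy sits. In an assay on isolated protein for inhibition of ceramide glucosyltransferase (Homo sapiens) (on this read-out higher numbers stand for weaker inhibition and lower numbers for stronger inhibition), compound 1 gives 150 nM, while compound 2 gives 50 nM, the lowest of the two numbers shown; the step of a 3.0-fold lower number from compound 1 to compound 2 (0.48 log units; beyond the scatter) separates them. Compound 3 `OC[C@@H]1[C@@H](O)[C@H](O)[C@@H](O)CN1CCCCCOCc1ccc(-c2ccccc2F)cc1` keeps the arrangement of compound 2 but carries fluoro in place of methoxy on an aromatic carbon. Within the data shown here, no measured step tests methoxy against fluoro; the step of a 3.0-fold lower number from compound 1 to compound 2 (0.48 log units; beyond the scatter) shows only that the place of the group matters. A shift beyond the scatter is therefore not expected, and compound 3 is estimated at 80 nM, between 30 nM and 250 nM, meaning an expected step of a 1.6-fold higher number from compound 2 to compound 3 (0.20 log units; within the scatter).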

Compound 3, half-maximal inhibitory concentration: 75 nM
Compound 3: the middle estimate sits 1.1-fold (0.03 log units) above what was measured; the measured number falls inside the stated range.
By their numbers in this assay, from the lowest: compounds 2, 3 and 1 (each within the scatter of the next, the first and the last beyond it).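

On an aromatic carbon ortho to a large group, fluoro, with its 1 heavy atom and 0 hydrogen-bond acceptors, can stand in for methoxy in this assay with no change beyond the scatter: the step of a 1.5-fold higher number from compound 2 to compound 3 (0.18 log units; within the scatter) is within it. The step of a 2.0-fold lower number from compound 1 to compound 3 (0.30 log units; within the scatter) is also within the scatter, so compound 3 cannot be separated from compound 1, although compound 2 can. Open, on these data alone, is whether a 3-fluorophenyl group, an amine or a carboxylic acid would read alike here, and no measurement on hand explains these numbers.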